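A few compounds are considered here, and "the series" means these few. Any claim that something is new, unique, unknown or untested is made for them only; others in the source may bear on it.

Measured so far in an assay on isolated protein for inhibition of Amine oxidase [flavin-containing] B (Homo sapiens), read by fluorescence and Amplex Red, with stated times of 15 min and 20 min; a higher number here means a weaker inhibitor, a lower number a stronger inhibitor:
compound 1 `Oc1ccc(O)c(/C=N/c2ccc(OCc3ccccc3)cc2)c1` gives 1230 nM
compound 2 `COc1ccc(/C=N/c2ccc(OCc3ccccc3)cc2)c(O)c1` gives 23600 nM

Compound 2 holds the highest of the two numbers; compound 1 differs from it in more than one place, so nothing is drawn from that gap. Compound 3 `Oc1ccccc1/C=N/c1ccc(OCc2ccccc2)cc1` carries hydrogen in place of methoxy on an aromatic carbon. Within the data shown here, no step between measured compounds guides this change. A small drop in the number is expected, within or only just beyond the scatter, as the step of a 2.0-fold lower number from compound 2 to compound 3 (0.29 log units; within the scatter) expresses. In this assay compound 3 is estimated at 12000 nM, with a range from 3000 nM to 50000 nM.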

Compound 3, half-maximal inhibitory concentration: 25100 nM
Compound 3: the middle estimate sits 2.1-fold (0.32 log units) below what was measured, within the range that was stated.
By their numbers in this assay, from the lowest: compound 1; then compounds 2 and 3 (each within the scatter of the next).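

In this assay, exchanging methoxy for hydrogen on this aromatic carbon, meta to a hydroxy group, changes nothing beyond the scatter (a 1.1-fold higher number from compound 2 to compound 3 (0.03 log units; within the scatter)). Exchanging hydroxy for hydrogen on an aromatic carbon costs far more (a 20-fold higher number from compound 1 to compound 3 (1.31 log units; beyond the scatter)), so the two groups do not count alike on this core. Nothing available explains that difference. On these data alone, it remains open whether hydroxy on the carbon that carries methoxy in compound 2 would match the result of compound 1. Whether an amine or a fluorine there would follow hydroxy or methoxy also stays unanswered.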